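Dimethylphenyl for methoxyphenyl on a weakly active spirooxindole core

The source may hold more compounds than are shown below. What is called first, only, known or untested is meant among the compounds shown, and "the series" means these compounds.

Compound 3, with the structure `COc1ccccc1-n1nncc1CN1C(=O)C2(C(C#N)=C(N)Oc3c2c2nc4ccccc4nc2c2ccccc32)c2ccccc21`, has in a functional assay on MCF7 cells (Homo sapiens) for antiproliferative activity, read by MTT assay, with a stated time of 48 h (on this read-out higher numbers stand for weaker inhibition and lower numbers for stronger inhibition), only a limit, since compound 3 is reported as > 50000 nM. The same holds for compound 1, `N#CC1=C(N)Oc2c(c3nc4ccccc4nc3c3ccccc23)C12C(=O)N(Cc1cnnn1-c1ccccc1Cl)c1ccccc12`, which in this assay gives > 50000 nM, also a limit. Within the data shown here, compound 2, `N#CC1=C(N)Oc2c(c3nc4ccccc4nc3c3ccccc23)C12C(=O)N(Cc1cnnn1-c1cccc(Cl)c1)c1ccccc12`, is the only member of the set with a number: in this assay compound 2 gives 43600 nM. The steps among these three are small or unreadable: an at least 1.1-fold lower number from compound 1 to compound 2 (0.05 log units; that floor lies within the scatter), an at least 1.1-fold higher number from compound 2 to compound 3 (0.05 log units; that floor lies within the scatter), and a step that the two limits leave unreadable from compound 1 to compound 3. Two of the three values sit at the same ceiling, as the limit of > 50000 nM in this assay, at which 2 of the 3 values shown sit, records.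

Compound 4, `Cc1ccc(-n2nncc2CN2C(=O)C3(C(C#N)=C(N)Oc4c3c3nc5ccccc5nc3c3ccccc43)c3ccccc32)cc1C`, differs from compound 3 only at the aryl group on the triazole nitrogen: 3,4-dimethylphenyl in place of 2-methoxyphenyl on an aromatic nitrogen. Every aryl variation measured so far has left this assay at or near its upper limit, so compound 4 is expected to behave alike, with a step of a number no higher from compound 3 to compound 4 (the limit leaves the size open) that is expected to stay within the scatter. Compound 4 is therefore estimated at 50000 nM, with a range from 25000 nM to 100000 nM, and a good chance that only a limit is reported.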

Compound 4, half-maximal inhibitory concentration: > 50000 nM
Compound 4 gave a limit, no number; the forecaster's own chance of this, stated with the estimate: 60%; the middle value sits exactly at the limit.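

With 3,4-dimethylphenyl on the aromatic nitrogen, an aryl group of carbon only that lacks the hydrogen-bond acceptor of 2-methoxyphenyl, compound 4 still gives only a limit in this assay, so its steps from compound 1 and compound 3 cannot be read. Among these compounds, the one readable step is an at least 1.1-fold higher number from compound 2 to compound 4 (0.05 log units; that floor lies within the scatter), which shows no difference from the 3-chlorophenyl group beyond the scatter. The ceiling now covers most of the set: the limit of > 50000 nM in this assay, at which 3 of the 4 values shown sit.

On these data alone, how far these aryl groups differ beneath that ceiling stays unknown, so it is open whether the aryl group at this position influences the read-out at all. As far as these compounds go, it is also open whether an amine or a carboxylic acid on the aryl ring, or a longer chain in its place, would yield a readable number.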